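From a Methoxy Group to a Chloro Group

The source may hold more compounds than are shown below. What is called first, only, known or untested is meant among the compounds shown, and "the series" means these compounds.

In a functional assay on the whole organism (strain Charles-Foster albino) for inhibition, with Rattus norvegicus as the target, read by paw edema, at a dose of 50 mg/kg by the oral route (a lower number here means less inhibition, a higher number more inhibition at the dose given (going by the name of the read-out)), compound 1 `COc1ccc(/C=N/n2c(CSc3nnc(-c4ccncc4)o3)nc3ccccc3c2=O)cc1` gives 20%. For the measured compounds named here, the only other measured compound, compound 2 `COc1ccc(/C=N/n2c(CSc3nnc(-c4ccncc4)o3)nc3ccc(Br)cc3c2=O)cc1`, gives 24.4%, and the step of a number 4.4 percentage points higher from compound 1 to compound 2 (within the scatter) lies within the scatter, so the two cannot be told apart. Compound 3 `O=c1c2ccccc2nc(CSc2nnc(-c3ccncc3)o2)n1/N=C/c1ccc(Cl)cc1` differs from compound 1 by chloro in place of methoxy on an aromatic carbon. Going by the values given here, the single measured step concerns bromo in place of hydrogen, not the methoxy group, so it offers no direct guide, and no step beyond the scatter is expected in this assay. Compound 3 is therefore expected to give about 22%, within a range from 12% to 32%. The expected step is a number 2 percentage points higher from compound 1 to compound 3 (within the scatter).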

Compound 3, a percentage reported as inhibition, in the whole organism at one dose (the size of the read-out at that dose, not a potency): 23.7%
Compound 3: the middle estimate sits 1.7 percentage points below what was measured; low and high end bracket the measured number.
By their numbers in this assay, from the lowest: compounds 1, 3 and 2 (each within the scatter of the next).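

In this assay, chloro in place of methoxy on this aromatic carbon gives a number 3.7 percentage points higher from compound 1 to compound 3 (within the scatter). For the compounds shown here, this is the first reading at this position, since the earlier step concerned bromo on another part of the molecule, and methoxy and chloro cannot be told apart here. No measured evidence explains this result. Still open, going by these compounds, is whether an amine, a carboxylic acid or a longer chain such as butoxy at this place would give a step beyond the scatter.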